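The compounds below may be only part of what the source reports. "The series", "measured", "known", "first", "only" and "open" are said of these compounds alone.

Compound 1 `CCOC(=O)c1ccc(-c2nn(Cc3cccc(F)c3)c3ccccc23)cc1` gives in a functional assay on cells (Platelet, Homo sapiens) for inhibition (on this read-out lower numbers stand for stronger inhibition and higher numbers for weaker inhibition), only the limit > 10000 nM.
Compound 2 `CCOC(=O)c1ccc(-c2nn(Cc3ccc(F)cc3)c3ccccc23)cc1` gives in this assay only the limit > 10000 nM.
Compound 3 `CCOC(=O)c1ccc(-c2nn(-c3ccoc3)c3ccccc23)cc1` gives in this assay only the limit > 10000 nM.

Compound 1 thus stands at the limit of this assay, and no number is known for it; the same holds for compound 2 and compound 3, which is summed up in the limit of > 10000 nM in this assay, at which 3 of the 3 values shown sit. The step that the two limits leave unreadable from compound 1 to compound 2 and the step that the two limits leave unreadable from compound 1 to compound 3 are therefore both unreadable. Compound 4 `CCCCn1nc(-c2ccc(C(=O)OCC)cc2)c2ccccc21` differs from compound 1 by propyl in place of 3-fluorophenyl on a saturated chain carbon bound to an aromatic nitrogen. Among the compounds with values here, no measured step swaps an aromatic group for a plain chain, so nothing read here points toward stronger inhibition. Compound 4 is expected to remain at the limit, with an estimate of 20000 nM ranging from 6000 nM to 70000 nM. The expected step is a step that the limit leaves unreadable from compound 1 to compound 4.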

Compound 4, half-maximal inhibitory concentration: > 10000 nM
Compound 4: a limit, no number (the forecaster's own chance of this, stated with the estimate: 85%); the middle value is on the limit's open side.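

Within the data shown here, no step from compound 1, compound 2 or compound 3 to compound 4 can be read, since all four give only limits, not numbers, in this assay: the limit of > 10000 nM in this assay, at which 4 of the 4 values shown sit. The compounds shown leave open how strongly any of them inhibits, and whether any group on the aromatic nitrogen would give a measurable value.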